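Removing the Hydroxy from the Lactone Core of Compound 3

A few compounds are considered here, and "the series" means these few. Any claim that something is new, unique, unknown or untested is made for them only; others in the source may bear on it.

Compound 1, `CO[C@H]1CCN2O[C@]34C=C[C@H](O)C[C@]3(OC(=O)C4)[C@@H]2C1`: > 10000 nM
Compound 2, `CO[C@H]1CCN2O[C@H]3C=CC[C@@]4(OC(=O)C=C34)[C@@H]2C1`: > 10000 nM
Compound 3, `O=C1C=C2C=C[C@H](O)C[C@]2(c2ccccn2)O1`: > 10000 nM

All three measured compounds were tested in an ADME assay on SK-MEL-2 cells (Homo sapiens) for cytotoxicity, read by sulforhodamine B assay, with a stated time of 48 h; a lower number here means a stronger inhibitor, a higher number a weaker inhibitor. Compound 1 gives > 10000 nM there, which is a limit of the assay and not a number. Compound 2 likewise gives > 10000 nM in this assay, again only a limit. Compound 3 gives > 10000 nM in this assay, and this too is a limit rather than a measured number. Compound 3 therefore stands at the limit of > 10000 nM in this assay, at which 3 of the 3 values shown sit, and nothing in the data separates it from the other two.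

Within the data shown here, no step between measured compounds that differ in one place is available, so no measured guidance exists for the change at hand. Compound 4, `O=C1C=C2C=CCC[C@]2(c2ccccn2)O1`, differs from compound 3 in one way: hydrogen in place of hydroxy on a saturated ring carbon. Among the measured compounds shown here, since compound 3 already sits at the limit of this assay, any step from it cannot be read from the data, and the account expects no step in this assay beyond the usual scatter in either direction. Compound 4 is expected to give about 20000 nM in this assay, within a range of 8000 nM to 60000 nM. This estimate corresponds to an expected step that the limit leaves unreadable from compound 3 to compound 4, and most likely compound 4 will again be reported only as a limit.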

Compound 4, half-maximal inhibitory concentration: > 10000 nM
Compound 4: a limit, no number (the forecaster's own chance of this, stated with the estimate: 85%); the middle value lies beyond the limit too.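

Among these compounds, compound 4 gives > 10000 nM in this assay, which is a limit and not a number, so no step from compound 3 to compound 4 can be read: the limit of > 10000 nM in this assay, at which 4 of the 4 values shown sit. The compounds shown leave open whether hydrogen in place of hydroxy on a saturated ring carbon changes anything in this assay, and how the four compounds rank there.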